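The source may hold more compounds than are shown below. What is called first, only, known or untested is meant among the compounds shown, and "the series" means these compounds.

Compound 1 `CCCCCCCC/C=C\CCCCCCC(=O)c1ccccc1` is a ketone on a long unsaturated chain. In an assay on isolated protein for inhibition of Fatty-acid amide hydrolase 1 (Homo sapiens) (on this read-out higher numbers stand for weaker inhibition and lower numbers for stronger inhibition), compound 1 gives only a limit, > 100000 nM, which is the limit of > 100000 nM in this assay, at which 1 of the 3 values shown sits. Two related ketones have been measured as well. Compound 2 `CCCCCCCC/C=C\CCCCCCC(=O)c1nc2cccc(C)c2o1` gives 13000 nM in this assay. Compound 3 `O=C(CCCCCCc1ccccc1)c1nnn[nH]1` gives only a limit, > 1000 nM, which is the limit of > 1000 nM in this assay, at which 1 of the 3 values shown sits. The unmeasured compound 4 `CCCCCCCC/C=C\CCCCCCC(=O)c1ccncn1` differs from compound 1 by pyrimidin-4-yl in place of phenyl on a carbonyl carbon. Going by the values given here, no measured pair isolates this change; the values of compound 1 and compound 2 show only that another aromatic ring in place of phenyl on this chain can yield a number rather than a limit. Compound 4 is therefore expected to inhibit more strongly, by a step estimated at an at least 100-fold lower number from compound 1 to compound 4 (2.00 log units; beyond the scatter). Compound 4 is estimated at 1000 nM, between 100 nM and 15000 nM.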

Compound 4, inhibition constant: 110 nM
The estimate for compound 4 lay 9.1-fold (0.96 log units) above the measured number; the range from low to high includes it.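

In this assay, the change from phenyl to pyrimidin-4-yl on a carbonyl carbon, with the unsaturated chain kept, gives an at least 900-fold lower number from compound 1 to compound 4 (2.95 log units; beyond the scatter). The earlier compounds shown here held no pair differing only in this place, and this pair shows that the ring alone can turn a limit into a measured number on this chain. The size of the step is only a bound, as compound 1 stands at a limit: the limit of > 100000 nM in this assay, at which 1 of the 4 values shown sits.

Going by these compounds, what a pyridin-2-yl ring would give on the same carbonyl carbon remains open. So does whether a saturated chain would keep this gain.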